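This account rests on a few compounds, and the source may have more. Where it says the series, first, only, none or still open, it means among the compounds named here.

Compound 2 `O=C(Nc1cccc(-n2cc(-c3ccncc3)c(-c3cc(O)cc(Cl)c3)n2)c1)Nc1ccc(Cl)c(C(F)(F)F)c1` stands second highest of the three numbers in a functional assay on SW-620 cells (Homo sapiens) for inhibition, read by sulforhodamine B assay, with a stated time of 48 h, tested at 10 uM (a lower number here means a stronger effect, a higher number a weaker effect of the compound at the concentration tested), where compound 2 gives -33.6%. Compound 3 `O=C(Nc1cccc(-n2cc(-c3ccncc3)c(-c3cc(O)cc(Cl)c3)n2)c1)Nc1ccc(Cl)c(Cl)c1` gives -33.8% in this assay, and compound 1 `COc1cc(Cl)cc(-c2nn(-c3cccc(NC(=O)c4ccc(Cl)c(Cl)c4)c3)cc2-c2ccncc2)c1` gives 84.2%. Within the data shown here, the only measured step, a number 0.2 percentage points lower from compound 2 to compound 3 (within the scatter), concerns a different change and says nothing about the one at hand. Compound 4 `COc1cc(Cl)cc(-c2nn(-c3cccc(NC(=O)Nc4ccc(Cl)c(C(F)(F)F)c4)c3)cc2-c2ccncc2)c1` differs from compound 2 by methyl in place of hydrogen on an oxygen on an aromatic ring. Among the measured compounds shown here, no measured step bears directly on this change; compound 1 carries the methoxy group but differs from compound 2 in more than one place, so its value is only a loose pointer. Compound 4 is therefore expected to give about 15%, somewhere between -40% and 85%, an expected step of a number 48.6 percentage points higher from compound 2 to compound 4 (beyond the scatter) that remains uncertain.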

Compound 4, a percentage reported as activity, at one concentration (the size of the read-out at that concentration, not a potency): 12.7%
The estimate for compound 4 lay 2.3 percentage points above the measured number; low and high end bracket the measured number.
By their numbers in this assay, from the lowest: compounds 3 and 2 (each within the scatter of the next); then compound 4; then compound 1.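

In this assay, among these compounds, the change from hydroxy to methoxy weakens the effect, with a number 46.3 percentage points higher from compound 2 to compound 4 (beyond the scatter) as the first direct reading at this oxygen, so the group there is not interchangeable. With methoxy held in place, (4-chloro-3-(trifluoromethyl)phenyl)amino in place of 3,4-dichlorophenyl on the carbonyl carbon gives a number 71.5 percentage points lower from compound 1 to compound 4 (beyond the scatter) and thus strengthens the effect substantially. Nothing available explains either step. As far as these compounds go, it remains open whether an ethoxy group or an amine in place of the hydroxy would retain the effect, and whether a carboxylic acid would be tolerated there.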